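Swapping (naphthalen-2-yl)methyl for pyrimidin-5-yl

A few compounds are considered here, and "the series" means these few. Any claim that something is new, unique, unknown or untested is made for them only; others in the source may bear on it.

In a functional assay on HCT-116 cells (Homo sapiens) for inhibition, read by MTT assay, with a stated time of 72 h (a lower number here means a stronger inhibitor of growth, a higher number a weaker inhibitor of growth), compound 2 (`O[C@H](COCCOC[C@@H](O)Cc1cn(Cc2ccc3ccccc3c2)nn1)Cc1ccc(-c2ccccc2)cc1`) gives 8600 nM and sits at the weak end of the three measured compounds. Compound 3 (`O[C@H](COCCOC[C@@H](O)Cc1cn(Cc2cccc(-c3ccccc3)c2)nn1)Cc1ccc(-c2ccccc2)cc1`) gives 7200 nM and cannot be told apart from compound 2. Compound 1 (`CC1=C(C)C(=O)C(CCCCCCCCCCn2cc(C[C@H](O)COCCOC[C@@H](O)Cc3ccc(-c4ccccc4)cc3)nn2)=C(C)C1=O`) gives 900 nM and lies clearly lower than both.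

Compound 4 (`O[C@H](COCCOC[C@@H](O)Cc1cn(-c2cncnc2)nn1)Cc1ccc(-c2ccccc2)cc1`) carries pyrimidin-5-yl in place of (naphthalen-2-yl)methyl on an aromatic nitrogen. For the measured compounds named here, the one measured step at this place (a 1.2-fold lower number from compound 2 to compound 3 (0.08 log units; within the scatter)) swapped one carbon-only aromatic group for another and bears on this change only loosely. Going by the values given here, no measured compound has hetero atoms in this group. A modest step toward weaker growth inhibition is expected (a 1.6-fold higher number from compound 2 to compound 4 (0.21 log units; within the scatter)). For compound 4 the estimated value is 14000 nM (6000 nM to 40000 nM as the expected range).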

Compound 4, concentration for 50% growth inhibition: > 100000 nM
Compound 4: no number, only a limit (the forecaster's own chance of this, stated with the estimate: 25%); at least 7.1-fold (0.85 log units) between middle value and limit.
By their numbers in this assay, from the lowest: compound 1; then compounds 3 and 2 (each within the scatter of the next). At a limit, above all of these: compound 4.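

In this assay, compound 4 gives no number, only a limit of the assay: the limit of > 100000 nM in this assay, at which 1 of the 4 values shown sits. Putting pyrimidin-5-yl in place of (naphthalen-2-yl)methyl on the aromatic nitrogen gives an at least 11-fold higher number from compound 2 to compound 4 (1.06 log units; beyond the scatter), so this position does respond to the group it carries. The earlier swap between carbon-only aromatic groups, a 1.2-fold lower number from compound 2 to compound 3 (0.08 log units; within the scatter), had shown no such response.

This change alters ring count, the methyl link and the ring nitrogens all at once, and the compounds shown cannot separate these. Going by these compounds, whether a plain phenyl or a pyrimidin-5-ylmethyl group on this nitrogen would retain growth inhibition remains open.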